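Swapping the Aryl Group for Benzyl on the Amine Nitrogen

The source may hold more compounds than are shown below. What is called first, only, known or untested is meant among the compounds shown, and "the series" means these compounds.

Compound 1 `Cc1ccc(S(=O)(=O)/N=C(/CCNC2=CC(=O)c3ccccc3C2=O)Nc2ccc(F)cc2)cc1` gives 9330 nM in a functional assay on A549 cells (Homo sapiens) for cytotoxicity, read by MTT assay, with a stated time of 48 h; a lower number here means a stronger inhibitor, a higher number a weaker inhibitor. Compound 2 `Cc1ccc(S(=O)(=O)/N=C(/CCNC2=CC(=O)c3ccccc3C2=O)Nc2cccc(C)c2)cc1` gives 18700 nM in this assay. Compound 3 `COc1ccc(N/C(CCNC2=CC(=O)c3ccccc3C2=O)=N\S(=O)(=O)c2ccc(C)cc2)cc1OC` gives 20500 nM in this assay.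

Compound 3 has the highest number of the three: against compound 2 the gap is a 1.1-fold higher number from compound 2 to compound 3 (0.04 log units; within the scatter), and against compound 1 it is a 2.2-fold higher number from compound 1 to compound 3 (0.34 log units; beyond the scatter). Compound 4 `Cc1ccc(S(=O)(=O)/N=C(/CCNC2=CC(=O)c3ccccc3C2=O)NCc2ccccc2)cc1` alters the group on the amine nitrogen: benzyl in place of 3,4-dimethoxyphenyl on an amine nitrogen. The steps already seen all exchange that same group and were small: a 2.0-fold higher number from compound 1 to compound 2 (0.30 log units; within the scatter) and a 2.2-fold higher number from compound 1 to compound 3 (0.34 log units; beyond the scatter), alongside a 1.1-fold higher number from compound 2 to compound 3 (0.04 log units; within the scatter). A benzyl group has not been tried here, so a step of similar size in either direction, or none beyond the scatter, is expected in this assay. The estimate for compound 4 is 15000 nM, with a range from 6000 nM to 40000 nM. The expected step is a 1.4-fold lower number from compound 3 to compound 4 (0.14 log units; within the scatter).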

Compound 4, half-maximal inhibitory concentration: 7410 nM
Compound 4: middle estimate off by 2.0-fold (0.31 log units), on the high side; measured number inside the range.
By their numbers in this assay, from the lowest: compounds 4, 1, 2 and 3 (each within the scatter of the next, the first and the last beyond it).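

With benzyl on the amine nitrogen in this assay, a 2.8-fold lower number from compound 3 to compound 4 (0.44 log units; beyond the scatter) and a 2.5-fold lower number from compound 2 to compound 4 (0.40 log units; beyond the scatter) are both modest steps beyond the scatter, whereas a 1.3-fold lower number from compound 1 to compound 4 (0.10 log units; within the scatter) stays within it. This shows that benzyl can replace the substituted phenyl groups here without a higher number, and compound 4 cannot be ordered against compound 1. Nothing available explains these steps.

Going by these compounds, it remains open whether a phenethyl group, with its longer chain, would keep this level. The same question stands for a benzyl group carrying fluorine on its ring.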